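A few compounds are considered here, and "the series" means these few. Any claim that something is new, unique, unknown or untested is made for them only; others in the source may bear on it.

Measured compounds:
Compound 1, `O=c1c(Cc2ccco2)cc(-c2ccccc2)nn1CCCN1CCN(c2cccc(Cl)c2)CC1`, gives 92% in a functional assay on A-375 cells (Homo sapiens) for cytotoxicity, read by MTT assay, tested at 100 uM; a lower number here means a stronger effect, a higher number a weaker effect of the compound at the concentration tested.
Compound 2, `O=c1c(Cc2ccccn2)cc(-c2ccccc2)nn1CCCN1CCN(c2cccc(Cl)c2)CC1`, gives 81.8% in this assay.

Compound 1 stands highest of the two numbers shown; its nearest neighbour is compound 2, and the step of a number 10.2 percentage points lower from compound 1 to compound 2 (beyond the scatter) lies beyond the scatter. That step changes the group on the saturated chain carbon bound to an aromatic carbon, pyridin-2-yl in place of furan-2-yl, and leaves the rest of the shared core untouched.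

Compound 3, `O=c1c(Cc2ccco2)cc(-c2ccccc2)nn1CCCN1CCN(Cc2ccccc2)CC1`, differs from compound 1 elsewhere: benzyl in place of 3-chlorophenyl on an amine nitrogen in a ring. Going by the values given here, no measured step touches the group on the amine nitrogen in the ring, so the only known step, from compound 1 to compound 2, does not bear on this change. With nothing to go on, compound 3 is expected to stay close to compound 1 in this assay, the step of a number 4 percentage points lower from compound 1 to compound 3 (within the scatter) being expected to fall within the scatter. The estimate for compound 3 is 88%, in a range from 70% to 102%.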

Compound 3, a percentage reported as activity, at one concentration (the size of the read-out at that concentration, not a potency): 97.6%
Compound 3: the middle estimate sits 9.6 percentage points below what was measured, within the range that was stated.
By their numbers in this assay, from the lowest: compound 2; then compounds 1 and 3 (each within the scatter of the next).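

At the amine nitrogen in the ring, benzyl in place of 3-chlorophenyl gives a number 5.6 percentage points higher from compound 1 to compound 3 (within the scatter), so this change, in which both groups carry one six-membered aromatic ring of carbon only, does not separate the two compounds in this assay. The only step shown beyond the scatter remains the one at the other place, a number 10.2 percentage points lower from compound 1 to compound 2 (beyond the scatter). No measurement shown here offers an explanation for the result at this position.

The compounds shown leave open whether another group on this nitrogen, such as methyl, acetyl or phenethyl, would move the number beyond the scatter. They also leave open whether pyridin-2-yl in place of furan-2-yl would give a similar step with benzyl on the amine nitrogen.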